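Swapping an Aryl Amine for Cyclohexyl on the Quinone Core

The compounds below may be only part of what the source reports. "The series", "measured", "known", "first", "only" and "open" are said of these compounds alone.

Compound 1 `O=C1C=C(NC2CCCCC2)C(=O)c2c1nc1n2[C@H]2OC[C@@H](O)[C@H]2OC1` gives only a limit of the assay in a functional assay on ECa-109 cells for inhibition, with ECa-109 cell line (Homo sapiens) as the target, read by sulforhodamine B assay (a higher number here means a weaker inhibitor, a lower number a stronger inhibitor), > 16000 nM.
Compound 2 `COc1ccccc1NC1=CC(=O)c2c(nc3n2[C@H]2OC[C@@H](O)[C@H]2OC3)C1=O` gives only a limit in this assay, > 4000 nM.
Compound 3 `CCOc1ccc(NC2=CC(=O)c3nc4n(c3C2=O)[C@H]2OC[C@@H](O)[C@H]2OC4)cc1` gives a number in this assay, 3210 nM.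

Compound 2 thus stands without a measured number, and only compound 3 supplies one among the three. Compound 4 `O=C1C(NC2CCCCC2)=CC(=O)c2c1nc1n2[C@H]2OC[C@@H](O)[C@H]2OC1` arises from compound 2 by cyclohexyl in place of 2-methoxyphenyl on an amine nitrogen. Among the compounds with values here, the one measured step that touches this change runs the other way: an at least 4.9-fold lower number from compound 1 to compound 3 (0.69 log units; beyond the scatter). Read in reverse, it points to a higher number for compound 4, and compound 1 on its own sits at the limit of > 16000 nM in this assay, at which 1 of the 3 values shown sits. Compound 4 is therefore expected to move to a higher number, a step that the limit leaves unreadable from compound 2 to compound 4, most likely ending at a limit. For compound 4 the estimate is 20000 nM, between 6000 nM and 60000 nM.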

Compound 4, half-maximal inhibitory concentration: > 16000 nM
Compound 4 gave a limit, no number; the forecaster's own chance of this, stated with the estimate: 85%; the middle value does not contradict the limit.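

In this assay, within the data shown here, compound 2 and compound 4 both give only limits, so no step between them can be read. The compounds shown leave open how far cyclohexyl and 2-methoxyphenyl on an amine nitrogen truly differ.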